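A few compounds are considered here, and "the series" means these few. Any claim that something is new, unique, unknown or untested is made for them only; others in the source may bear on it.

Compound 1 `O=S(=O)(NCCCCNCc1ccc(Br)cc1)c1cc(C(F)(F)F)cc(C(F)(F)F)c1` gives 2100 nM in a functional assay on MIA PaCa-2 cells (Homo sapiens) for inhibition, read by MTT assay, with a stated time of 72 h; a higher number here means a weaker inhibitor of growth, a lower number a stronger inhibitor of growth. Compound 2 `O=S(=O)(NCCCCCCNCc1ccc(Br)cc1)c1cccc(C(F)(F)F)c1` gives 5970 nM in this assay.

Within the data shown here, of the two numbers measured so far, compound 2 stands highest; the only other compound, compound 1, sits lower, and the gap between them lies beyond the usual scatter. Compound 1 and compound 2 differ in more than one place, so their two values are noted side by side without drawing a step from one to the other. Compound 3 `O=S(=O)(NCCCCCCNCc1ccc(Br)cc1)c1cc(C(F)(F)F)cc(C(F)(F)F)c1` has not yet been measured. It arises from compound 2 by trifluoromethyl in place of hydrogen on an aromatic carbon. Among the measured compounds shown here, no single-point step between measured compounds is available to set the size of such a change. Since compound 1, which also carries two trifluoromethyl groups, gives 2100 nM, a moderate move toward a lower number is expected, so compound 3 is estimated at 3000 nM with a range of 1200 nM to 7500 nM. The expected step of a 2.0-fold lower number from compound 2 to compound 3 (0.30 log units; within the scatter) is of a size that may or may not exceed the scatter.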

Compound 3, concentration for 50% growth inhibition: 2970 nM
The estimate for compound 3 lay 1.0-fold (0.00 log units) above the measured number; low and high end bracket the measured number.
By their numbers in this assay, from the lowest: compounds 1, 3 and 2 (each within the scatter of the next, the first and the last beyond it).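

In this assay, among these compounds, trifluoromethyl in place of hydrogen on this aromatic carbon gives a 2.0-fold lower number from compound 2 to compound 3 (0.30 log units; within the scatter), the first reading of this single change, and it stays within the scatter. With both trifluoromethyl groups present, the swap of (4-bromobenzyl)amino for 2-((4-bromobenzyl)amino)ethyl on the saturated chain carbon gives a 1.4-fold higher number from compound 1 to compound 3 (0.15 log units; within the scatter), which also stays within the scatter, so neither single change is resolved from the scatter in this assay. Nothing available explains either step.

From the compounds shown here alone, it remains open whether a different group on this aromatic carbon, such as a nitrile or a methoxy group, would give a step beyond the scatter. Going by these compounds, it is equally open whether a longer chain between the sulfonamide nitrogen and the (4-bromobenzyl)amino group would do so.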